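Swapping Trifluoromethyl for Amino on the Urea Partner

The compounds below may be only part of what the source reports. "The series", "measured", "known", "first", "only" and "open" are said of these compounds alone.

Compound 3 `CN1c2ccc(NC(=O)Nc3ccc(C(F)(F)F)cc3)cc2C(C)(C)C(=O)C1(C)C` was measured in an assay on isolated protein for binding affinity to stress-70 protein, mitochondrial (Homo sapiens) (a higher number here means weaker binding, a lower number tighter binding), and gave 1500 nM. Among the compounds measured so far, compound 1 `CC1(C)CCNc2ccc(NC(=O)Nc3ccc([N+](=O)[O-])cc3)cc21` gave 1100 nM, a number so close to that of compound 3 that the two cannot be told apart within the usual scatter of this assay. Compound 2 `CC1(C)CCNc2ccc(NC(=S)Nc3ccc(C(F)(F)F)cc3)cc21` gave 3300 nM, a higher number than that of compound 3 and one that lies beyond the scatter. Within the data shown here, no pair of these measured compounds differs in a single place, so nothing here speaks directly to the exchange that leads to compound 4 `CN1c2ccc(NC(=O)Nc3ccc(N)cc3)cc2C(C)(C)C(=O)C1(C)C`.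

The change from compound 3 to compound 4 is amino in place of trifluoromethyl on an aromatic carbon; the rest of the structure is kept. Among the measured compounds shown here, none of the measured compounds shows how compound 3 responds to this exchange, and compound 1 differs from compound 4 in more than one place, so the expectation rests only on the spread of numbers seen across the set. Compound 4 is expected to come in at about 2500 nM, with a plausible range from 800 nM to 8000 nM. This estimate amounts to a step of a 1.7-fold higher number from compound 3 to compound 4 (0.22 log units; within the scatter), expected to be modest and not clearly beyond the scatter of this assay.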

Compound 4, dissociation constant: 1100 nM
For compound 4 the middle estimate is 2.3-fold (0.36 log units) above the measured one, within the range that was stated.
By their numbers in this assay, from the lowest: compounds 1, 4 and 3 (each within the scatter of the next); then compound 2.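

In this assay, among these compounds, the exchange of trifluoromethyl for amino on an aromatic carbon, para to a large group, gives the first comparison in this set that differs in one place only: a 1.4-fold lower number from compound 3 to compound 4 (0.13 log units; within the scatter). The two compounds therefore cannot be told apart in this read-out, even though the exchange takes out a group of 4 heavy atoms with no hydrogen-bond donors or acceptors and puts in a group of 1 heavy atom with 1 hydrogen-bond donor and 1 hydrogen-bond acceptor. Nothing available bears on why these two compounds read alike.

On these data alone, a single pair cannot say whether this position accepts substituents in general, and how a carboxylic acid, a methoxy group or an acetylated amine would read at the same place on the core of compound 3 remains open. As far as these compounds go, it also remains open whether amino in place of trifluoromethyl would read the same way on the otherwise unchanged structure of compound 2, where the shared position carries trifluoromethyl on a different core and linker.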